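Replacing a Hydroxy Group With Phenethyl on the Shared Core

The source may hold more compounds than are shown below. What is called first, only, known or untested is meant among the compounds shown, and "the series" means these compounds.

For the measured compounds named here, compound 2 `COc1cc(OCc2cccc(O)c2)c2cc(-c3cn4nc(OC)sc4n3)oc2c1` gives 2700 nM in an assay on a cell-free system (plasma) for antagonist activity at proteinase-activated receptor 4 (Homo sapiens), with a stated time of 5 min, in the presence of a further agent that is not named here (on this read-out higher numbers stand for weaker inhibition and lower numbers for stronger inhibition), the higher of the two numbers measured so far. Its nearest neighbour, compound 1 `COc1cc(OCc2cccc(COc3ccccc3)c2)c2cc(-c3cn4nc(OC)sc4n3)oc2c1`, gives 600 nM. Going by the values given here, the one measured step, a 4.5-fold higher number from compound 1 to compound 2 (0.65 log units; beyond the scatter), shows that the bare hydroxy gives a weaker result than phenoxymethyl at the same place. Compound 3 `COc1cc(OCc2cccc(CCc3ccccc3)c2)c2cc(-c3cn4nc(OC)sc4n3)oc2c1` carries the change (phenethyl in place of hydroxy on an aromatic carbon), which, like the phenoxymethyl of compound 1, brings a six-membered aromatic ring of carbon only. Because compound 1 gives 600 nM, the expected step is a 3.9-fold lower number from compound 2 to compound 3 (0.59 log units; beyond the scatter). Compound 3 is estimated at 700 nM, between 250 nM and 2000 nM.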

Compound 3, half-maximal inhibitory concentration: 1200 nM
Estimate against measurement, compound 3: 1.7-fold (0.23 log units) below; low and high end bracket the measured number.
By their numbers in this assay, from the lowest: compounds 1 and 3 (each within the scatter of the next); then compound 2.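

Phenethyl, like phenoxymethyl, improves on the bare hydroxy at this position, with a 2.3-fold lower number from compound 2 to compound 3 (0.35 log units; beyond the scatter) in this assay. Benzyl in place of phenoxy on the saturated chain carbon gives a 2.0-fold higher number from compound 1 to compound 3 (0.30 log units; within the scatter) and so separates the two groups by no more than the usual spread of repeat measurements, which means the chain oxygen of phenoxymethyl is not shown to matter here. Nothing available explains either step. Still open, as far as these compounds go, is whether the terminal ring itself is needed, as a plain butyl chain would show. An amine or a carboxylic acid at the end of the chain is also untested among the compounds shown.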